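Swapping a Chloro Group for a Hydrazide Ether

A few compounds are considered here, and "the series" means these few. Any claim that something is new, unique, unknown or untested is made for them only; others in the source may bear on it.

Compound 1 `CC(C)c1ccc(-c2cc(-c3ccc4c(c3)CCCC4)nc(Cl)c2C#N)cc1` was tested in an ADME assay on RAW264.7 cells (Mus musculus) for cytotoxicity, with a stated time of 24 h (on this read-out lower numbers stand for stronger inhibition and higher numbers for weaker inhibition), where compound 1 gives 8400 nM. Within the data shown here, this is the only plain number in the set, so compound 1 is the sole reference point. Compound 2 `CC(C)c1ccc(-c2cc(-c3ccc4c(c3)CCCC4)nc3[nH]nc(N)c23)cc1` differs from compound 1 in more than one place and reaches only a boundary of the test: in this assay compound 2 gives > 50000 nM, which is a limit rather than a measured value. The other mark on the scale is the limit of > 50000 nM in this assay, at which 1 of the 2 values shown sits. Among the measured compounds shown here, no step between measured compounds is recorded.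

Compound 3 `CC(C)c1ccc(-c2cc(-c3ccc4c(c3)CCCC4)nc(OCC(=O)NN)c2C#N)cc1` has not yet been measured. It differs from compound 1 by (aminocarbamoyl)methoxy in place of chloro on an aromatic carbon, next to the ring nitrogen and ortho to a cyano group. For the measured compounds named here, no measured pair reports what such a swap does in this assay. The step from compound 1 to compound 3 is expected to be a 2.4-fold higher number from compound 1 to compound 3 (0.38 log units; beyond the scatter), toward a weaker effect, beyond the usual scatter. Compound 3 is accordingly estimated at 20000 nM, with an expected range from 6000 nM to 50000 nM.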

Compound 3, half-maximal inhibitory concentration: 27700 nM
Compound 3: middle estimate off by 1.4-fold (0.14 log units), on the low side; the range from low to high includes it.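

In this assay, putting (aminocarbamoyl)methoxy in place of chloro on this aromatic carbon gives a 3.3-fold higher number from compound 1 to compound 3 (0.52 log units; beyond the scatter), so this single change weakens the effect on the cells by a modest step that lies beyond the usual scatter. Among these compounds, this is the first direct reading for this position, and it shows that the position can carry a far larger chain, with 6 heavy atoms entering where 1 heavy atom leaves, while the compound still gives a plain measured number in this test. That number is not a limit, and the only limit in the set belongs to compound 2: the limit of > 50000 nM in this assay, at which 1 of the 3 values shown sits.

A single swap cannot show which part of the new chain goes with the step, since the ether oxygen, the carbonyl and the terminal nitrogens all enter together. Simpler groups on the same carbon, such as a methoxy group, an amine or a carboxylic acid on the same short chain, would help separate those parts, and the compounds shown also leave open whether the step would hold on a different core.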